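A few compounds are considered here, and "the series" means these few. Any claim that something is new, unique, unknown or untested is made for them only; others in the source may bear on it.

Of the compounds shown here, three have been measured in an assay on isolated protein for activation of cGMP-dependent protein kinase 1 (Homo sapiens), read by ADP-Glo, with stated times of 30 min and 2 h, in the presence of a further agent that is not named here; a lower number here means that less compound is needed, a higher number that more compound is needed for the effect. Compound 1, with the structure `Cc1cc(C(=O)O)ccc1C(C)N1CCC[C@H](O[C@H](CO)c2cc(Cl)cc(Cl)c2)[C@@H]1c1ccccc1`, gives 18000 nM in this assay. Compound 2, with the structure `COc1cccc([C@@H](CO)O[C@H]2CCCN(Cc3ccc(C(=O)O)cc3C)[C@H]2c2ccccc2)c1`, gives 81000 nM, a higher number that lies beyond the usual scatter. Compound 3, with the structure `Cc1cc(C(=O)O)ccc1CN1CCC[C@H](O[C@@H](CC(C)(C)O)c2cc(Cl)cc(Cl)c2)[C@@H]1c1ccccc1`, gives 330 nM, a far lower number, also beyond the scatter. Among these three results compound 1 thus holds the second highest number: compound 2 is its nearest neighbour and compound 3 its furthest.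

Compound 4, with the structure `O=C(O)C12CC(CN3CCC[C@H](O[C@H](CO)c4cc(Cl)cc(Cl)c4)[C@@H]3c3ccccc3)(C1)C2`, has not yet been measured in this assay. It is derived from compound 1 by one change on an amine nitrogen in a ring: a group of 9 heavy atoms (7 carbon, 2 oxygen; 2 four-membered non-aromatic rings of carbon only) in place of a group of 12 heavy atoms (10 carbon, 2 oxygen; one six-membered aromatic ring of carbon only), on an amine nitrogen in a ring. The aromatic ring carrying the acid is thus traded for a cage of two four-membered non-aromatic rings carrying the same acid.

Among the compounds with values here, no measured pair among the three compounds shows this kind of exchange, so its effect cannot be read from the numbers at hand. In the absence of such a comparison, the expected step from compound 1 to compound 4 in this assay is a 1.4-fold higher number from compound 1 to compound 4 (0.14 log units; within the scatter), which is within the scatter. Compound 4 is therefore estimated to give about 25000 nM in this assay, with a likely range from 6000 nM to 100000 nM.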

Compound 4, half-maximal effective concentration: 12000 nM
Compound 4: the middle estimate sits 2.1-fold (0.32 log units) above what was measured; low and high end bracket the measured number.
By their numbers in this assay, from the lowest: compound 3; then compounds 4 and 1 (each within the scatter of the next); then compound 2.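

In this assay, the exchange on the amine nitrogen in the ring gives a 1.5-fold lower number from compound 1 to compound 4 (0.18 log units; within the scatter), so this position accepts two four-membered non-aromatic rings of carbon only in place of a six-membered aromatic ring with no change that can be told from the scatter. For this pair, therefore, an aromatic ring in the group on that nitrogen is not required to keep the number where it stands, and a group of 9 heavy atoms serves as well as a group of 12 heavy atoms. No separate measurement on these compounds bears on why the exchange leaves the number in place.

This single pair cannot show whether the same exchange would hold on a compound with a different group on the ether oxygen, such as the chain carried by compound 3. It also leaves open how the number would respond if an amide or an amine took the place of the carboxylic acid on the cage, or if a longer chain linked the cage to the nitrogen.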